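Two Chlorines, Two Places: Expecting Compound 3

This account rests on a few compounds, and the source may have more. Where it says the series, first, only, none or still open, it means among the compounds named here.

Two compounds share a core and differ only in where a single chlorine sits. Compound 1 `Cn1c(N2N=C(c3ccccc3)CC2c2ccc(Cl)cc2)nc(-c2ccccc2)c(C#N)c1=O` carries the chlorine on the phenyl attached to the five-membered ring, and in a functional assay on MCF7 cells (Homo sapiens) for antiproliferative activity, with a stated time of 72 h (on this read-out higher numbers stand for weaker inhibition and lower numbers for stronger inhibition), compound 1 gives 3280 nM. Compound 2 `Cn1c(N2N=C(c3ccccc3)CC2c2ccccc2)nc(-c2ccc(Cl)cc2)c(C#N)c1=O` moves the chlorine to the phenyl on the core itself, and in this assay compound 2 gives 34400 nM, the highest of the two numbers and a gap to compound 1 well beyond the usual scatter. Compound 3 `Cn1c(N2N=C(c3ccccc3)CC2c2ccc(Cl)cc2)nc(-c2ccc(Cl)cc2)c(C#N)c1=O` keeps the chlorine of compound 2 and adds a second one: chloro in place of hydrogen on an aromatic carbon. For the measured compounds named here, no single step between measured compounds matches this change. From compound 2 to compound 3 the number is expected to fall by a moderate step, a 2.9-fold lower number from compound 2 to compound 3 (0.46 log units; beyond the scatter), since compound 1 with its chlorine in that place gave 3280 nM. Compound 3 is estimated at 12000 nM, within 3500 nM to 40000 nM.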

Compound 3, half-maximal inhibitory concentration: 46300 nM
Beside the measured number, compound 3's estimate is 3.9-fold (0.59 log units) below it, outside the stated range (above it).
By their numbers in this assay, from the lowest: compound 1; then compounds 2 and 3 (each within the scatter of the next).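

The same change, chloro in place of hydrogen on an aromatic carbon, has very different outcomes in this assay depending on which compound receives it and on which phenyl it lands. Made on compound 2, it gives a 1.3-fold higher number from compound 2 to compound 3 (0.13 log units; within the scatter) so the two compounds cannot be told apart, while made on the phenyl attached to the core of compound 1, it gives a 14-fold higher number from compound 1 to compound 3 (1.15 log units; beyond the scatter) and that step is large. With a chlorine already on the core's phenyl, the second chlorine does not restore the stronger inhibition of compound 1. Nothing measured here gives a reason for either step. The compounds shown leave open whether a methoxy group or an amine in the same place on either phenyl would behave like chloro, and how a compound with no chlorine at all compares with these three.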